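A few compounds are considered here, and "the series" means these few. Any claim that something is new, unique, unknown or untested is made for them only; others in the source may bear on it.

Series notes on compound 1 `CC(C)C(c1ccc(-c2ccc3cccc(F)c3c2)[nH]c1=O)N1CCCCS1(=O)=O` and its analogues in an ADME assay on microsomes from liver (Homo sapiens) for metabolic stability; on this read-out lower numbers stand for a shorter-lived compound and higher numbers for a longer-lived compound. Compound 1 gives 0.373 h, the highest of the three numbers to hand. Compound 2 `CC(C)C(c1ncco1)c1ccc(-c2ccc3cccc(F)c3c2)[nH]c1=O` gives 0.178 h in this assay, and compound 3 `CC(C)C(c1cnc(N)s1)c1ccc(-c2ccc3cccc(F)c3c2)[nH]c1=O` gives 0.178 h. The step of a 2.1-fold lower number from compound 1 to compound 2 (0.32 log units; beyond the scatter) and the step of a 2.1-fold lower number from compound 1 to compound 3 (0.32 log units; beyond the scatter) each replace the same ring on the saturated chain carbon bound to an aromatic carbon and a saturated chain carbon, and both run in the same direction; between the two smaller groups no change at the digits printed from compound 2 to compound 3 (within the scatter).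

Compound 4 `CC(C)C(CC(N)=O)c1ccc(-c2ccc3cccc(F)c3c2)[nH]c1=O` carries a further change at that place: a group of 4 heavy atoms (2 carbon, 1 nitrogen, 1 oxygen; no ring) in place of a group of 8 heavy atoms (4 carbon, 1 nitrogen, 2 oxygen, 1 sulfur; one six-membered non-aromatic ring with 2 hetero atoms), on a saturated chain carbon bound to an aromatic carbon and a saturated chain carbon. Nothing else in the structure moves. The two measured steps from compound 1 bear on it directly, each modest but beyond the scatter, each toward a shorter half-life. A step of similar size and direction is therefore expected. The half-life of compound 4 in this assay is estimated at 0.2 h, with a range from 0.1 h to 0.4 h. The expected step is a 1.9-fold lower number from compound 1 to compound 4 (0.27 log units; within the scatter).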

Compound 4, half-life: < 0.0667 h
Compound 4 was reported as a limit; the forecaster's own chance of this, stated with the estimate: 0%; middle value at least 2.9-fold (0.47 log units) away from the limit.
By their numbers in this assay, from the lowest: compounds 2 and 3 (each within the scatter of the next); then compound 1. At a limit, below all of these: compound 4.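

Compound 4 stands at a limit of this assay, not at a number: the limit of < 0.0667 h in this assay, at which 1 of the 4 values shown sits. At this place on the saturated chain carbon, the ring-free carbamoylmethyl group gives an at least 5.5-fold lower number from compound 1 to compound 4 (0.74 log units; beyond the scatter), so the half-life here can drop further than the two five-membered aromatic rings had shown. It also parts from both of those rings, with an at least 2.6-fold lower number from compound 2 to compound 4 (0.42 log units; beyond the scatter) and an at least 2.6-fold lower number from compound 3 to compound 4 (0.42 log units; beyond the scatter), whereas compound 2 and compound 3 had shown no difference beyond the scatter.

As far as these compounds go, how far compound 4 lies past its limit stays open, so the full size of these steps cannot be read. Also open, from the compounds shown here alone, is whether a carboxylic acid, an amine or a longer chain ending in the same carbonyl group would follow carbamoylmethyl or the ring-bearing groups at this place.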